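The source may hold more compounds than are shown below. What is called first, only, known or untested is meant among the compounds shown, and "the series" means these compounds.

Compound 1 `C/C(=C\CC/C(C)=C/CC[C@@H]1[C@@]2(C)CCC(=O)C(C)(C)[C@H]2CC[C@@]1(C)O)CC/C=C(\C)C(=O)OCc1cn(-c2ccccc2[N+](=O)[O-])nn1`, compound 2 `C#CCOC(=O)/C(C)=C/CC/C(C)=C/CC/C(C)=C/CC[C@@H]1[C@@]2(C)CCC(=O)C(C)(C)[C@H]2CC[C@@]1(C)O`, compound 3 `C/C(=C\CC/C(C)=C/CC[C@@H]1[C@@]2(C)CCC(=O)C(C)(C)[C@H]2CC[C@@]1(C)O)CC/C=C(\C)C(=O)OCc1cn(-c2cccc(Br)c2)nn1` and compound 4 `C/C(=C\CC/C(C)=C/CC[C@@H]1[C@@]2(C)CCC(=O)C(C)(C)[C@H]2CC[C@@]1(C)O)CC/C=C(\C)C(=O)OCc1cn(-c2ccc(C(C)(C)C)cc2)nn1` share one core and differ only in the group carried on the oxygen next to the carbonyl. In a functional assay on A549 cells (Homo sapiens) for antiproliferative activity, read by MTT assay, with a stated time of 48 h (on this read-out higher numbers stand for weaker inhibition and lower numbers for stronger inhibition), compound 2 gives 45100 nM. Compound 1 reaches only a limit of this assay, > 150000 nM. Compound 3 also stands at a limit, > 150000 nM, so no number is known for it. Two of the three values shown rest at that same limit (the limit of > 150000 nM in this assay, at which 2 of the 3 values shown sit). The change to compound 4 is 4-(tert-butyl)phenyl in place of 3-bromophenyl on an aromatic nitrogen. Going by the values given here, two measured steps touch this position: a step that the two limits leave unreadable from compound 1 to compound 3, and an at least 3.3-fold higher number from compound 2 to compound 3 (0.52 log units; beyond the scatter). Both aryl variants on the five-membered aromatic ring with 3 nitrogen remain unreadable at the limit. Compound 4 is therefore expected to stay there as well, around 160000 nM (range 60000 nM to 400000 nM). The expected step is a step that the limit leaves unreadable from compound 3 to compound 4.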

Compound 4, half-maximal inhibitory concentration: > 150000 nM
Compound 4 was reported as a limit (the forecaster's own chance of this, stated with the estimate: 75%); the middle value lies beyond the limit too.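

Going by these compounds alone, compound 4 stands as a limit in this assay at > 150000 nM and so no step from compound 1 or compound 3 to compound 4 can be read. How the aryl groups of compound 1, compound 3 and compound 4 rank against one another stays open: the limit of > 150000 nM in this assay, at which 3 of the 4 values shown sit.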